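A Ring Amine Opened at the Limit

The source may hold more compounds than are shown below. What is called first, only, known or untested is meant among the compounds shown, and "the series" means these compounds.

In a functional assay on SK-BR-3 cells (Homo sapiens) for antiproliferative activity (a lower number here means a stronger inhibitor, a higher number a weaker inhibitor), three compounds have been measured:
- compound 1 `CC(=O)Oc1ccc(C(=O)Nc2cc3ccc(OCC4CCN(C)C4)c(C)c3oc2=O)cc1CC=C(C)C` gives 880 nM
- compound 2 `CC(=O)Oc1ccc(C(=O)Nc2cc3ccc(OCC4CCCNC4)c(C)c3oc2=O)cc1CC=C(C)C` gives 620 nM
- compound 3 `CC(C)=CCc1cc(C(=O)Nc2cc3ccc(OCCCN4CCCCC4)c(C)c3oc2=O)ccc1O` gives > 50000 nM, which is a limit and not a number

Compound 3 stands at the limit of > 50000 nM in this assay, at which 1 of the 3 values shown sits. Its true position is therefore unknown, and only the limit can serve as the starting point for the next comparison.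

Compound 4 `CC(C)=CCc1cc(C(=O)Nc2cc3ccc(OCCCNCC(C)C)c(C)c3oc2=O)ccc1O` has isobutylamino in place of piperidin-1-yl on a saturated chain carbon, three bonds along the chain from an oxygen on an aromatic ring. For the measured compounds named here, no measured step makes this exact change. The nearest evidence is a 1.4-fold lower number from compound 1 to compound 2 (0.15 log units; within the scatter), where one saturated nitrogen ring replaces another at a similar place and the size of the step stays within the scatter. Compound 1 and compound 2 also differ from compound 3 elsewhere, so this step offers only limited guidance. On that basis, no step beyond the scatter is expected in this assay, and a result at the limit would be no surprise. The expected step is an at least 1.2-fold lower number from compound 3 to compound 4 (0.09 log units; that floor lies within the scatter). For compound 4 the estimated value is 40000 nM, with an expected range from 10000 nM to 50000 nM.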

Compound 4, half-maximal inhibitory concentration: 1030 nM
For compound 4 the middle estimate is 39-fold (1.59 log units) above the measured one; measured number outside the range, below it.
By their numbers in this assay, from the lowest: compounds 2, 1 and 4 (each within the scatter of the next). At a limit, above all of these: compound 3.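

In this assay, isobutylamino in place of piperidin-1-yl on a saturated chain carbon, three bonds along the chain from an oxygen on an aromatic ring, gives an at least 48-fold lower number from compound 3 to compound 4 (1.68 log units; beyond the scatter), so this position responds strongly to the change of amine, whereas the swap of one saturated nitrogen ring for another in the earlier pair, at a similar place on a different compound, gave only a 1.4-fold lower number from compound 1 to compound 2 (0.15 log units; within the scatter). The figure for compound 3, > 50000 nM, is a limit of the assay and not a number. The step from it can therefore be read only as a floor, and its true size remains unknown: the limit of > 50000 nM in this assay, at which 1 of the 4 values shown sits.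

The change removes a six-membered non-aromatic ring and also brings in a hydrogen-bond donor, and the compounds shown leave open which of these two differences goes with the step. Diethylamino on the same propyl chain would keep the open chain without the amine hydrogen, while a piperidin-4-ylamino group would keep a ring together with that hydrogen, and either could separate the two.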